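The source may report more compounds than this note shows. Statements on the series, on what has been measured and on what is new or still open speak of the compounds shown alone.

Going by the values given here, only two compounds have numbers so far. In a functional assay on PC-3 cells (Homo sapiens) for cytotoxicity, read by MTT assay (on this read-out higher numbers stand for weaker inhibition and lower numbers for stronger inhibition), compound 1 `COc1ccc2cc([C@H](C)c3nnc(SCc4c(Cl)cccc4Cl)n3-c3cccc(Cl)c3)ccc2c1` gives 165000 nM, and compound 2 `COc1ccc(CSc2nnc([C@@H](C)c3ccc4cc(OC)ccc4c3)n2-c2ccc(F)cc2)cc1` gives 400000 nM. That is the higher of the two numbers and so the weaker inhibition, with a gap beyond the usual scatter. These two compounds differ in more than one place, so their gap cannot be pinned on a single group. Compound 3 `COc1ccc2cc([C@H](C)c3nnc(SCc4c(Cl)cccc4Cl)n3-c3ccc(F)cc3)ccc2c1` departs from compound 2 in one place: 2,6-dichlorophenyl in place of 4-methoxyphenyl on a saturated chain carbon bound to a sulfur, with 2,6-dichlorophenyl in place of 4-methoxyphenyl on a saturated chain carbon bound to a sulfur. Among the compounds with values here, no measured pair shows this change alone, so any forecast is loose. Compound 1 also carries the 2,6-dichlorobenzyl group and gives 165000 nM, which suggests a modest drop in the number in this assay, near the edge of the scatter. The expected change is a 2.1-fold lower number from compound 2 to compound 3 (0.32 log units; beyond the scatter). For compound 3 the estimated value is 190000 nM, with an expected range of 80000 nM to 380000 nM.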

Compound 3, half-maximal inhibitory concentration: 216000 nM
Beside the measured number, compound 3's estimate is 1.1-fold (0.06 log units) below it, within the range that was stated.
By their numbers in this assay, from the lowest: compounds 1, 3 and 2 (each within the scatter of the next, the first and the last beyond it).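

In this assay, going by these compounds alone, putting 2,6-dichlorophenyl in place of 4-methoxyphenyl on a saturated chain carbon bound to a sulfur gives a 1.9-fold lower number from compound 2 to compound 3 (0.27 log units; within the scatter) as the first reading of this change alone, so the change has no effect here that can be told apart from repeat-measurement noise. On the aromatic nitrogen, 4-fluorophenyl in place of 3-chlorophenyl gives a 1.3-fold higher number from compound 1 to compound 3 (0.12 log units; within the scatter) and is equally hard to tell from noise. Compound 3 therefore links compound 1 and compound 2, dividing a gap that could not be pinned on one group into two single-place steps, neither beyond the scatter on its own.

No measurement here explains the size of either step. From the compounds shown here alone, whether a different group on that chain carbon, such as an amine or a carboxylic acid, would move the number beyond the scatter remains open.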